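From 3-methylphenyl to 2,6-dimethylpyrimidin-4-yl

The source may hold more compounds than are shown below. What is called first, only, known or untested is meant among the compounds shown, and "the series" means these compounds.

Compound 3 `COc1ccc2nc(C)cc(OCC(=O)Nc3cccc(C)c3)c2c1` is the only one of the three measured compounds that gives a number: in a toxicity assay on HepG2 cells (Homo sapiens) for inhibition, read by CellTiter-Glo, with a stated time of 48 h (a higher number here means a weaker inhibitor, a lower number a stronger inhibitor), compound 3 gives 39800 nM. Compound 1 `Cc1cc(C)cc(NC(=O)COc2cc(C)nc3ccccc23)c1` reaches only a limit of the assay, > 100000 nM. Compound 2 `Cc1cc(C)cc(NC(=O)COc2cc(C)nc3ccc(Cl)cc23)c1` likewise reaches only a limit, > 100000 nM. For the measured compounds named here, the single measured step, a step that the two limits leave unreadable from compound 1 to compound 2, cannot be sized because the limit of > 100000 nM in this assay, at which 2 of the 3 values shown sit, holds both of its values.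

Compound 4 `COc1ccc2nc(C)cc(OCC(=O)Nc3cc(C)nc(C)n3)c2c1` differs from compound 3 by 2,6-dimethylpyrimidin-4-yl in place of 3-methylphenyl on an amide-type nitrogen. Going by the values given here, no measured step touches this change, so the expectation rests on compound 3 alone. For compound 4 the expected step is a 1.3-fold higher number from compound 3 to compound 4 (0.10 log units; within the scatter), small enough to stay inside the usual scatter. Compound 4 is thus estimated at 50000 nM, with a range from 20000 nM to 120000 nM.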

Compound 4, half-maximal inhibitory concentration: > 100000 nM
Compound 4: a limit, no number (the forecaster's own chance of this, stated with the estimate: 40%); middle value at least 2.0-fold (0.30 log units) away from the limit.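

In this assay, for the compounds shown here, 2,6-dimethylpyrimidin-4-yl in place of 3-methylphenyl on the amide-type nitrogen gives an at least 2.5-fold higher number from compound 3 to compound 4 (0.40 log units; beyond the scatter), the first step in this set that can be sized, and it points to weaker inhibition. The value of compound 4, > 100000 nM, is a limit of the assay and not a number, so the step has a floor but no full size. Compound 3 alone now gives a number, while the others share one ceiling: the limit of > 100000 nM in this assay, at which 3 of the 4 values shown sit.

The step from compound 1 to compound 2 still cannot be read. On these data alone, whether a pyridin-2-yl ring or a plain phenyl ring on this nitrogen would give a number stays open.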